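The source may hold more compounds than are shown below. What is called first, only, known or untested is meant among the compounds shown, and "the series" means these compounds.

This set concerns three compounds built on one shared core, with a single substituent that varies. Compound 1 `Cc1cc(NC(=O)Nc2ccc(C(=O)O)cc2)c2ccccc2n1` was tested in an ADME assay on HepG2 cells (Homo sapiens) for cytotoxicity, with a stated time of 72 h; on this read-out higher numbers stand for an effect only at larger amounts of compound and lower numbers for an effect already at smaller amounts. In this assay compound 1 gives > 25000 nM, which is a limit of the assay rather than a measured number. Compound 2 `Cc1cc(NC(=O)Nc2ccccc2C(F)(F)F)c2ccccc2n1` in this assay likewise gives > 25000 nM, again a limit and not a number. Going by the values given here, both values fall at the limit of > 25000 nM in this assay, at which 2 of the 2 values shown sit, so compound 1 stands exactly where every value so far stands, with no number to rank it by. Compound 3 `Cc1cc(NC(=O)Nc2ccc(F)cc2)c2ccccc2n1` has not yet been measured in this assay; it differs from compound 1 by fluoro in place of carboxy on an aromatic carbon. Among the compounds with values here, no step between two measured compounds exists here to guide the expectation. The expected step is a step that the limit leaves unreadable from compound 1 to compound 3, that is, none beyond the usual scatter. Compound 3 is therefore expected to give 30000 nM, within a range from 8000 nM to 100000 nM, and quite possibly only a limit once more.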

Compound 3, half-maximal effective concentration: > 25000 nM
Compound 3 was reported as a limit; the forecaster's own chance of this, stated with the estimate: 75%; the middle value is on the limit's open side.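

Going by these compounds alone, compound 1 and compound 3 both sit at a limit of the assay rather than at a measured number, so no step between them can be read: the limit of > 25000 nM in this assay, at which 3 of the 3 values shown sit.
Still open, from the compounds shown here alone, is whether fluoro in place of carboxy changes the result in this assay at all, and how compound 1, compound 2 and compound 3 would rank.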